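The compounds below may be only part of what the source reports. "The series", "measured", "known", "first", "only" and "open" are said of these compounds alone.

Compound 1, `CCC1(Cc2ccccc2)OS(=O)(=O)C=C1OCc1ccc(F)cc1`: in an ADME assay on HEL cells (Homo sapiens) for cytotoxicity, with a stated time of 3 days (a higher number here means that more compound is tolerated, a lower number that less compound is tolerated), compound 1 gives >= 50000 nM, which is a limit of the assay rather than a number.
Compound 2, `CCC1(Cc2ccccc2)OS(=O)(=O)C=C1OCC1CCCCC1`: compound 2 gives >= 200000 nM, also a limit.
Compound 3, `CCC1(Cc2ccccc2)OS(=O)(=O)C=C1OCc1cccc(Cl)c1`: compound 3 gives >= 20000 nM, again a limit.

Within the data shown here, compound 3 therefore stands only at a limit, and the two other values shown are limits as well, so no compound can be placed above or below another. The steps between them are accordingly unreadable: a step that the two limits leave unreadable from compound 1 to compound 2, a step that the two limits leave unreadable from compound 1 to compound 3 and a step that the two limits leave unreadable from compound 2 to compound 3 give no size and no direction.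

Compound 4, `CCC1(Cc2ccccc2)OS(=O)(=O)C=C1OCc1ccc(Br)cc1`, differs from compound 3 in one place: 4-bromophenyl in place of 3-chlorophenyl on a saturated chain carbon bound to an oxygen on an unsaturated carbon. Among the measured compounds shown here, the steps that bear on this change are the two that end at compound 3, from compound 1 and from compound 2, and both leave their size unreadable, as the evidence shows only limits at the limit of >= 20000 nM in this assay, at which 1 of the 3 values shown sits, the limit of >= 50000 nM in this assay, at which 1 of the 3 values shown sits, and (the limit of >= 200000 nM in this assay, at which 1 of the 3 values shown sits). No step beyond the scatter can be expected from them in either direction; what is expected is that compound 4 again reaches a limit in this assay.

Compound 4 is estimated at 50000 nM, within a range from 10000 nM to 200000 nM. This estimate means an expected step that the limit leaves unreadable from compound 3 to compound 4.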

Compound 4, minimum cytotoxic concentration: 80000 nM
Compound 4: middle estimate off by 1.6-fold (0.20 log units), on the low side; the measured number falls inside the stated range.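

Among these compounds, compound 4 gives the first actual number rather than a limit: in this assay compound 4 gives 80000 nM. That number makes one step at this position readable, since putting 4-bromophenyl in place of cyclohexyl gives an at least 2.5-fold lower number from compound 2 to compound 4 (0.39 log units; beyond the scatter), so for this pair the group on the saturated chain carbon does change how much compound the cells tolerate, and the aromatic group is the less tolerated one. The steps to compound 4 from compound 1 and from compound 3 cannot be read, so nothing yet separates 4-bromophenyl from 4-fluorophenyl or from 3-chlorophenyl.

On these data alone, it remains open whether this lower number goes with the aromatic ring itself or with the bromo on it, a question that a plain phenyl at this place would help to settle. Among the compounds shown here, how the cells would tolerate an amine or a carboxylic acid on that ring, or a longer chain in place of the ring, also remains open, and the single number here gives no basis for predicting either.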